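The compounds below may be only part of what the source reports. "The series", "measured", "known", "first", "only" and "open" are said of these compounds alone.

In a physicochemical assay for solubility, read by HPLC, with a stated time of 24 h (on this read-out higher numbers stand for higher solubility and lower numbers for lower solubility), three compounds have been measured: compound 1 `O=C1CSC(=O)N1C[C@H]1CN(c2ccc(-n3cc(-c4ccccn4)cn3)c(F)c2)C(=O)O1` gives 26900 nM; compound 2 `CS(=O)(=O)NC[C@H]1CN(c2ccc(-n3cc(-c4ccccn4)cn3)c(F)c2)C(=O)O1` gives 2300 nM; compound 3 `CN(C)S(=O)(=O)NC[C@H]1CN(c2ccc(-n3cc(-c4ccccn4)cn3)c(F)c2)C(=O)O1` gives 472000 nM.

Compound 3 stands highest of the three: the step of an 18-fold higher number from compound 1 to compound 3 (1.24 log units; beyond the scatter) and the step of a 210-fold higher number from compound 2 to compound 3 (2.31 log units; beyond the scatter) both lie beyond the scatter. Compound 4 `O=C1O[C@@H](CNC(=O)C(F)(F)F)CN1c1ccc(-n2cc(-c3ccccn3)cn2)c(F)c1` differs from it by (trifluoromethyl)carbonyl in place of dimethylsulfamoyl on an amine nitrogen. Within the data shown here, no measured step covers this exchange, so it can be read only indirectly. The steps of a 12-fold lower number from compound 1 to compound 2 (1.07 log units; beyond the scatter) and an 18-fold higher number from compound 1 to compound 3 (1.24 log units; beyond the scatter) show that exchanges at this side chain move this assay by large amounts in either direction. From compound 3 a large downward step is therefore expected, a 16-fold lower number from compound 3 to compound 4 (1.20 log units; beyond the scatter). Compound 4 is estimated at 30000 nM, within 3000 nM to 300000 nM.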

Compound 4, solubility: 114000 nM
For compound 4 the middle estimate is 3.8-fold (0.58 log units) below the measured one; the measured number falls inside the stated range.
By their numbers in this assay, from the lowest: compound 2; then compound 1; then compound 4; then compound 3.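

At this amine nitrogen in this assay, a carbonyl group takes the place of a sulfonyl group without reaching either extreme of the series: a 4.1-fold lower number from compound 3 to compound 4 (0.62 log units; beyond the scatter) is modest, while a 50-fold higher number from compound 2 to compound 4 (1.70 log units; beyond the scatter) is large. Exchanging 2,4-dioxo-1,3-thiazolidin-3-yl for the ((trifluoromethyl)carbonyl)amino group gives a 4.2-fold higher number from compound 1 to compound 4 (0.63 log units; beyond the scatter) and so places compound 4 above compound 1 and below compound 3. Nothing available explains these differences.

Still open, from the compounds shown here alone, is whether acetyl, with methyl in place of trifluoromethyl, would stay close to compound 4. Dimethylcarbamoyl on the same nitrogen would show whether dimethylamino also raises the number on a carbonyl carbon.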